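This account rests on a few compounds, and the source may have more. Where it says the series, first, only, none or still open, it means among the compounds named here.

Measured compounds:
compound 1, `COc1cccc(CNCCCNc2ccnc3cc(-c4ccccc4)ccc23)c1O` — 9.47
compound 2, `COc1ccc(F)cc1CNCCCNc1ccnc2cc(-c3ccccc3)ccc12` — 9.47

Both compounds were measured in a physicochemical assay for acid dissociation. Compound 1 gives 9.47 in this assay, and compound 2 gives 9.47, so the two stand level at the digits shown: the step of no change at the digits printed from compound 1 to compound 2 (within the scatter) lies within the scatter of this kind of measurement. Compound 1 therefore has no measured neighbour that differs from it beyond the scatter.

The unmeasured compound 3, `COc1cccc(CNCCCNc2ccnc3cc(Cc4cc(C)cc(C)c4)ccc23)c1O`, is reached from compound 1 by a single change: 3,5-dimethylbenzyl in place of phenyl on an aromatic carbon. For the measured compounds named here, this change sits on an aromatic carbon of the shared core, whereas the only measured step exchanged the group on a saturated chain carbon bound to an amine nitrogen and left this assay unchanged. Going by the values given here, no measured step bears directly on the aromatic-carbon position, so the expectation rests on the fact that the part of the molecule carrying the amine nitrogens is kept, and that the one change recorded so far did not move the read-out. The step of no change at the digits printed from compound 1 to compound 3 (within the scatter) is therefore expected to stay within the scatter. Compound 3 is estimated at 9.47, with a range from 9.1 to 9.8.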

Compound 3, acid dissociation constant: 9.47
Compound 3: the middle estimate sits on the measured number at the digits printed; the measured number falls inside the stated range.
By their numbers in this assay, from the lowest: compounds 1, 2 and 3 (each within the scatter of the next).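

In this assay, putting 3,5-dimethylbenzyl in place of phenyl on an aromatic carbon of the shared core gives no change at the digits printed from compound 1 to compound 3 (within the scatter), so this position now has a measured step of its own; the earlier pair spoke only to a group on a saturated chain carbon bound to an amine nitrogen. The change is a real increase in size, with 9 heavy atoms entering where 6 leave, yet both groups consist of carbon only, each with one six-membered aromatic ring and with 0 hydrogen-bond donors and 0 hydrogen-bond acceptors, so the result covers a larger all-carbon group and nothing more. No supporting measurement is available to explain this outcome.

Still open, going by these compounds, is how the read-out would respond at this aromatic carbon to a group that contains atoms other than carbon, such as an amine or a carboxylic acid. The three compounds also share one chain between the amine nitrogens, so they leave unanswered what a longer chain there would do to the read-out in this assay.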